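The source may report more compounds than this note shows. Statements on the series, on what has been measured and on what is new or still open speak of the compounds shown alone.

Measured so far in an ADME assay on HEK293 cells (Homo sapiens) for cytotoxicity, read by CellTiter-Glo and resazurin assay, with a stated time of 72 h; on this read-out lower numbers stand for an effect already at smaller amounts and higher numbers for an effect only at larger amounts of compound:
- compound 1 `CCOC(=O)CCCCCOc1cccc(CN(C(=O)c2ccccc2)C(C)C)c1` — > 26000 nM
- compound 2 `CCOC(=O)CCCCCOc1cccc(CN(C(=O)c2ccc(Br)cc2)C(C)C)c1` — > 26000 nM

Compound 1 in this assay shows only a limit, > 26000 nM. Compound 2 in this assay likewise shows only a limit, > 26000 nM. Among the compounds with values here, the one step between them, a step that the two limits leave unreadable from compound 1 to compound 2, is therefore not readable, both values sitting at the limit of > 26000 nM in this assay, at which 2 of the 2 values shown sit. Compound 2 thus stands at the limit, with nothing in the series placing it above or below compound 1.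

Compound 3 `CCOC(=O)CCCCCOc1cccc(CNC(C)C)c1` differs from compound 2 by hydrogen in place of (4-bromophenyl)carbonyl on an amine nitrogen. Within the data shown here, no measured step bears directly on this change; the only step in hand, a step that the two limits leave unreadable from compound 1 to compound 2, was unreadable and concerns a different position. With both measured values at the limit, the expectation for compound 3 is that it too reaches no readable number in this assay, and the step that the limit leaves unreadable from compound 2 to compound 3 is expected to stay within the scatter. Compound 3 is estimated at 40000 nM, between 15000 nM and 150000 nM, most likely reported again as a limit.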

Compound 3, half-maximal effective concentration: > 26000 nM
Compound 3 gave a limit, no number; the forecaster's own chance of this, stated with the estimate: 80%; the middle value lies beyond the limit too.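

In this assay compound 3 gives > 26000 nM, which is a limit and not a number. The steps from compound 1 and from compound 2 to compound 3 cannot be read, and all three compounds stand together: the limit of > 26000 nM in this assay, at which 3 of the 3 values shown sit.

The compounds shown leave open at what concentration any of the three has an effect in this assay.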